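Compound 3: what a swapped benzyl-side group may do

The source may hold more compounds than are shown below. What is called first, only, known or untested is meant among the compounds shown, and "the series" means these compounds.

Compound 1 `COc1ccc(CS(=O)(=O)/C=C/c2c(OC)cccc2OC)c(N)c1`: 750 nM
Compound 2 `COc1ccc(CS(=O)(=O)/C=C/c2c(OC)cc(OC)cc2OC)c(N)c1`: 25 nM
Compound 3 `COc1cc(OC)c(/C=C/S(=O)(=O)Cc2ccc(Cl)c(N)c2)c(OC)c1`: not yet measured

In a functional assay on K562 cells (Homo sapiens) for cytotoxicity, read by trypan blue exclusion, with a stated time of 96 h (a higher number here means a weaker inhibitor, a lower number a stronger inhibitor), compound 2 holds the lower of the two numbers at 25 nM, which makes it the stronger inhibitor of the pair. The next structural change is 3-amino-4-chlorophenyl in place of 2-amino-4-methoxyphenyl on a saturated chain carbon bound to a sulfonyl sulfur. For the measured compounds named here, only one measured step exists, a 30-fold lower number from compound 1 to compound 2 (1.48 log units; beyond the scatter), and it came from methoxy in place of hydrogen on an aromatic carbon. That step leaves the exchanged group untouched, so it offers no direct guide to size. It does show that a single change can shift the number substantially, and compound 2 starts from the low end at 25 nM. A moderate move towards a weaker number therefore seems likely. The expected change is a 4.0-fold higher number from compound 2 to compound 3 (0.60 log units; beyond the scatter). For compound 3 the estimated value is 100 nM, with an expected range of 20 nM to 500 nM.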

Compound 3, half-maximal inhibitory concentration: 10 nM
For compound 3 the middle estimate is 10-fold (1.00 log units) above the measured one; measured number outside the range, below it.
By their numbers in this assay, from the lowest: compound 3; then compound 2; then compound 1.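

Compound 1 and compound 2 carry the same group at the saturated chain carbon bound to a sulfonyl sulfur, so they said nothing about this place. In this assay, exchanging 2-amino-4-methoxyphenyl for 3-amino-4-chlorophenyl there gives a 2.5-fold lower number from compound 2 to compound 3 (0.40 log units; beyond the scatter), which shows that this place accepts a different ring substitution without any loss of strength. The exchange removes the methoxy, brings in chlorine and changes where the amino group sits, all in one step, and nothing measured here explains the lower number.

Still open, going by these compounds, is which part of the exchange matters: a phenyl group carrying only the chlorine, or only the amino group, would separate the two. Also open, on these data alone, is whether a fluorine or a methyl group in place of the chlorine would keep the number near that of compound 3.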